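The source may hold more compounds than are shown below. What is called first, only, known or untested is meant among the compounds shown, and "the series" means these compounds.

Measured so far in an assay on COS-7 cells for agonist activity at Free fatty acid receptor 1 (Homo sapiens), read by scintillation counting and inositol phosphate accumulation, with a stated time of 90 min; on this read-out lower numbers stand for an effect already at smaller amounts and higher numbers for an effect only at larger amounts of compound:

- compound 1 `Cc1cc(=O)oc2cc(OCc3nc(N)nc(Nc4ccc(Cl)cc4)n3)ccc12`: 32500 nM
- compound 2 `Cc1cc(=O)oc2cc(OCc3nc(N)nc(Nc4ccc(F)cc4)n3)ccc12`: 18300 nM

Compound 2 holds the lower of the two numbers in this assay, but its nearest neighbour is compound 1, and the step of a 1.8-fold lower number from compound 1 to compound 2 (0.25 log units; within the scatter) stays within the scatter, so the two compounds cannot be told apart on these data. Both share the same core and differ only in the halogen on the aromatic carbon of the phenylamino group.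

Compound 3 `Cc1ccc(Nc2nc(N)nc(COc3ccc4c(C)cc(=O)oc4c3)n2)cc1` has not yet been measured in this assay. Against compound 2 the change is methyl in place of fluoro on an aromatic carbon. Among the measured compounds shown here, only one measured step bears on this place, a 1.8-fold lower number from compound 1 to compound 2 (0.25 log units; within the scatter), which exchanged one halogen for another at the same carbon and produced no change beyond the scatter. For the measured compounds named here, no measured step exchanges a halogen for a methyl, so the data give no direction for this change; the single comparison available suggests that substitution at this carbon is tolerated without a large shift.

The expectation for compound 3 is therefore a step of a 1.1-fold higher number from compound 2 to compound 3 (0.04 log units; within the scatter) that lies within the scatter, with the estimate for compound 3 in this assay placed at 20000 nM, range 8000 nM to 50000 nM.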

Compound 3, half-maximal effective concentration: 1790 nM
Estimate against measurement, compound 3: 11-fold (1.05 log units) above, outside the stated range (below it).
By their numbers in this assay, from the lowest: compound 3; then compounds 2 and 1 (each within the scatter of the next).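

In this assay, methyl in place of halogen on this aromatic carbon, para to a large group, gives a 10-fold lower number from compound 2 to compound 3 (1.01 log units; beyond the scatter) and likewise an 18-fold lower number from compound 1 to compound 3 (1.26 log units; beyond the scatter), so both steps lie beyond the scatter, while the exchange of chloro for fluoro at the same carbon gave only a 1.8-fold lower number from compound 1 to compound 2 (0.25 log units; within the scatter) and did not. The carbon therefore does not treat all small substituents alike: the halogen pair had suggested a flat response, but that held only between the two halogens, and a change of a single heavy atom here is enough to separate compound 3 from both of them, leaving compound 3 the most potent of the three on this read-out. Nothing shown explains why methyl parts from fluoro and chloro here.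

On these data alone, whether the gain is particular to methyl remains open: an ethyl group, a methoxy group or a trifluoromethyl group at this carbon would show whether it holds, grows or is lost, and the plain phenyl with hydrogen there would show whether methyl improves on the unsubstituted ring or the halogens fall short of it. Also open, as far as these compounds go, is whether a methyl on another carbon of this ring gives a step of similar size.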